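The compounds below may be only part of what the source reports. "The series", "measured", "known", "first", "only" and "open" are said of these compounds alone.

In a functional assay on KBVIN cells (Homo sapiens) for antiproliferative activity, read by sulforhodamine B assay, with a stated time of 3 days (a lower number here means that less compound is needed, a higher number that more compound is needed for the effect), compound 2 `CCC1=C(O)c2c(oc(-c3cc(C)ccc3C)cc2=O)C(CC)(CC)C1=O` gives 3.41 uM and compound 1 `CCC1=C(O)c2c(oc(-c3cc(C)c(C)cc3C)cc2=O)C(CC)(CC)C1=O` gives 4.37 uM, so the two lie within the scatter of each other. Compound 3 `CCC1=C(O)c2c(oc(-c3cc(C)cc(C)c3)cc2=O)C(CC)(CC)C1=O` is not yet measured. It carries 3,5-dimethylphenyl in place of 2,5-dimethylphenyl on an aromatic carbon. Going by the values given here, the only measured step that bears on this is a 1.3-fold lower number from compound 1 to compound 2 (0.11 log units; within the scatter), and it exchanges a methyl for hydrogen, so it is indirect evidence. No shift beyond the scatter is therefore expected in this assay. The expected change is a 1.0-fold higher number from compound 2 to compound 3 (0.01 log units; within the scatter). Compound 3 is estimated at 3.5 uM, within a range of 1.5 uM to 8 uM.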

Compound 3, concentration for half-maximal effect: 0.45 uM
Estimate against measurement, compound 3: 7.8-fold (0.89 log units) above; measured number below the stated range.
By their numbers in this assay, from the lowest: compound 3; then compounds 2 and 1 (each within the scatter of the next).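

In this assay, 3,5-dimethylphenyl in place of 2,5-dimethylphenyl gives a 7.6-fold lower number from compound 2 to compound 3 (0.88 log units; beyond the scatter) and keeps the same atoms, so the arrangement of the methyl groups on this aryl ring matters, not only their number. 3,5-dimethylphenyl in place of 2,4,5-trimethylphenyl gives a 9.7-fold lower number from compound 1 to compound 3 (0.99 log units; beyond the scatter), whereas the earlier step between compound 1 and compound 2 stayed within the scatter. Nothing available explains the difference.

As far as these compounds go, whether both methyl groups of compound 3 are needed remains open. Also open, from the compounds shown here alone, is how plain phenyl, or methoxy or chlorine at these ring places, would compare.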